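The source may report more compounds than this note shows. Statements on the series, on what has been measured and on what is new or still open speak of the compounds shown alone.

Compound 1 `CCCCn1cc(C(=O)O)c(=O)c2cc(F)c(Cl)cc21` and compound 2 `CCCCn1cc(C(=O)O)c(=O)c2cc(F)c(N(C)C)cc21` share one core and differ in a single group on an aromatic carbon. In an ADME assay on J774.1 cells (Mus musculus) for cytotoxicity, read by resazurin assay, with a stated time of 48 h (on this read-out lower numbers stand for stronger inhibition and higher numbers for weaker inhibition), compound 1 gives > 100000 nM, which is a limit of the assay rather than a measured number. In this assay compound 2 gives > 100000 nM, again a limit and not a number. The step that the two limits leave unreadable from compound 1 to compound 2 therefore cannot be read in size or direction. Both values sit on the same boundary, as shown by the limit of > 100000 nM in this assay, at which 2 of the 2 values shown sit. Compound 2 thus stands at the limit of this assay, with no finer number attached to it.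

Compound 3 `CCCCn1cc(C(=O)O)c(=O)c2cc(F)c(N3CCCCC3)cc21` differs from compound 2 in one place: piperidin-1-yl in place of dimethylamino on an aromatic carbon. Among the compounds with values here, the only measured step touching this position is unreadable, so it offers no size to carry over. The expectation is therefore a step that the limit leaves unreadable from compound 2 to compound 3 that does not go beyond the usual scatter, with compound 3 most likely remaining at the limit of this assay. Compound 3 is estimated at 150000 nM, with a range from 50000 nM to 400000 nM.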

Compound 3, half-maximal inhibitory concentration: 93000 nM
Beside the measured number, compound 3's estimate is 1.6-fold (0.21 log units) above it, and the stated range covers the measured number.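

Within the data shown here, compound 3 brings the first true number at this position: in this assay compound 3 gives 93000 nM, so a group carrying a six-membered non-aromatic ring on this aromatic carbon can be read on the scale itself. The change to piperidin-1-yl from dimethylamino gives an at least 1.0-fold lower number from compound 2 to compound 3 (0.03 log units; that floor lies within the scatter), and the change to piperidin-1-yl from chloro gives an at least 1.0-fold lower number from compound 1 to compound 3 (0.03 log units; that floor lies within the scatter); each figure is only a floor, and since both floors lie within the scatter, neither establishes a real change in cytotoxicity. The two earlier compounds still supply no number for comparison, as compound 1 and compound 2 each stand at a limit of the assay: the limit of > 100000 nM in this assay, at which 2 of the 3 values shown sit.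

The compounds shown leave open how this position would read with a ring holding a second hetero atom, such as morpholine or piperazine, or with an open-chain amine such as diethylamino. With a single number in hand, no trend across groups at this position can yet be drawn.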